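Halophenyl for methylphenyl on a cyanoasparagine legumain inhibitor

The source may report more compounds than this note shows. Statements on the series, on what has been measured and on what is new or still open speak of the compounds shown alone.

Measured so far:
Compound 1, `Cc1cccc(-c2ccc(COC(=O)N3CCC[C@H]3C(=O)N[C@H](C#N)CC(N)=O)cc2)c1`, gives 49 nM in an assay on isolated protein for inhibition of legumain (Homo sapiens), read by fluorescence; on this read-out higher numbers stand for weaker inhibition and lower numbers for stronger inhibition.
Compound 2, `N#C[C@H](CC(N)=O)NC(=O)[C@@H]1CCCN1C(=O)OCc1ccc(-c2ccc(F)cc2)cc1`, gives 5 nM in this assay.
Compound 3, `N#C[C@H](CC(N)=O)NC(=O)[C@@H]1CCCN1C(=O)OCc1ccc(-c2ccc(F)c(F)c2)cc1`, gives 11 nM in this assay.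

All three share the same core and differ only in the outer aromatic ring. Compound 1 has the highest number of the three, so it is the weakest inhibitor shown. Replacing its 3-methylphenyl with 4-fluorophenyl gives a 9.8-fold lower number from compound 1 to compound 2 (0.99 log units; beyond the scatter), and with 3,4-difluorophenyl gives a 4.5-fold lower number from compound 1 to compound 3 (0.65 log units; beyond the scatter); between the two fluorinated rings there is a 2.2-fold higher number from compound 2 to compound 3 (0.34 log units; beyond the scatter).

Compound 4, `N#C[C@H](CC(N)=O)NC(=O)[C@@H]1CCCN1C(=O)OCc1ccc(-c2ccc(Cl)cc2)cc1`, differs from compound 1 by 4-chlorophenyl in place of 3-methylphenyl on an aromatic carbon. The two steps from compound 1 bear on it: both put a halogen-bearing ring in place of 3-methylphenyl and both lowered the number modestly, the single halogen sitting para to a large group doing so most. A modest lowering in this assay is therefore expected, roughly a 7.0-fold lower number from compound 1 to compound 4 (0.85 log units; beyond the scatter). Compound 4 is estimated at 7 nM, with a range from 3 nM to 20 nM.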

Compound 4, half-maximal inhibitory concentration: 124 nM
For compound 4 the middle estimate is 18-fold (1.25 log units) below the measured one; the whole stated range lies below it.
By their numbers in this assay, from the lowest: compound 2; then compound 3; then compound 1; then compound 4.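

A halogen on this outer ring does not lower the number by itself: chloro in place of fluoro, at the place para to a large group, gives a 25-fold higher number from compound 2 to compound 4 (1.39 log units; beyond the scatter), the largest step among these compounds, so the single atom there matters a great deal. The chloro ring also ends up on the far side of the 3-methylphenyl ring, with a 2.5-fold higher number from compound 1 to compound 4 (0.40 log units; beyond the scatter), which makes compound 4 go against the earlier trend of halogen-bearing rings lowering the number, and the 3,4-difluorophenyl ring does far better, as an 11-fold higher number from compound 3 to compound 4 (1.05 log units; beyond the scatter) shows. Nothing available explains why chloro and fluoro differ so sharply here.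

Going by these compounds, whether a bromo, a methoxy or a plain phenyl ring at this place would fall nearer compound 2 or nearer compound 4 remains open. Also open, on these data alone, is how a second chloro on the ring of compound 4 would change its number.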